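A few compounds are considered here, and "the series" means these few. Any claim that something is new, unique, unknown or untested is made for them only; others in the source may bear on it.

Compound 3 `COc1cccc(Cc2cnc(CCc3ccc(-c4ccccc4C(=O)O)cc3)[nH]2)c1` stands at the high end of the three measured compounds: in an in vitro functional assay on cells for agonist activity at Bombesin receptor subtype-3 (Homo sapiens), read by luminescence and calcium flux (a lower number here means that less compound is needed, a higher number that more compound is needed for the effect), compound 3 gives 4120 nM, while compound 1 `O=C(O)c1ccccc1-c1ccc(CCc2ncc(CC3CCCCC3)[nH]2)cc1` gives 41 nM and compound 2 `O=C(O)c1ccccc1-c1ccc(CCc2ncc(CC3CCC3)[nH]2)cc1` gives 588 nM. Compound 4 `Cc1cccc(Cc2cnc(CCc3ccc(-c4ccccc4C(=O)O)cc3)[nH]2)c1` differs from compound 3 by methyl in place of methoxy on an aromatic carbon. Among the measured compounds shown here, none of the measured steps probes this aromatic carbon: a 14-fold higher number from compound 1 to compound 2 (1.16 log units; beyond the scatter), a 100-fold higher number from compound 1 to compound 3 (2.00 log units; beyond the scatter) and a 7.0-fold higher number from compound 2 to compound 3 (0.85 log units; beyond the scatter) each exchange the whole group on the saturated chain carbon, and none varies a substituent on the 3-methoxyphenyl ring. Those steps show that this part of the molecule matters strongly in this assay, but the exchange of methoxy for methyl is a far smaller alteration than any of them. Compound 4 is therefore expected to move only slightly, a 1.4-fold lower number from compound 3 to compound 4 (0.14 log units; within the scatter), with an estimate of 3000 nM, between 900 nM and 10000 nM.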

Compound 4, half-maximal effective concentration: 4310 nM
The estimate for compound 4 lay 1.4-fold (0.16 log units) below the measured number, within the range that was stated.
By their numbers in this assay, from the lowest: compound 1; then compound 2; then compounds 3 and 4 (each within the scatter of the next).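

In this assay, methyl in place of methoxy on this aromatic carbon, meta to a large group, leaves the result within the scatter (a 1.0-fold higher number from compound 3 to compound 4 (0.02 log units; within the scatter)). A change on the ring itself therefore has no readable effect here, even though a hydrogen-bond acceptor leaves with the methoxy. The 3-methylphenyl group also stays well behind both saturated rings (a 7.3-fold higher number from compound 2 to compound 4 (0.87 log units; beyond the scatter); a 110-fold higher number from compound 1 to compound 4 (2.02 log units; beyond the scatter)). No evidence is available to explain this result. As far as these compounds go, whether a hydroxyl, an amine or a chlorine on this carbon would also leave the number unchanged remains open, as does the effect of a methyl on another carbon of the ring.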